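From compound 1 to compound 4: bromo for difluoromethoxy

A few compounds are considered here, and "the series" means these few. Any claim that something is new, unique, unknown or untested is made for them only; others in the source may bear on it.

Compound 1 `CCN(CC)c1cc2[nH]c(C3CCCCC3)nc2cc1NC(=O)c1ccc(OC(F)F)cc1` was examined in an ADME assay on Vero cells (Chlorocebus sabaeus) for cytotoxicity, read by resazurin assay, with a stated time of 3 days; on this read-out lower numbers stand for stronger inhibition and higher numbers for weaker inhibition. In this assay compound 1 gives > 100 ug/mL, which is a limit of the assay rather than a number. Compound 2 `CN(C)c1cc2[nH]c(C3CCCCC3)nc2cc1NC(=O)c1ccc(OC(F)F)cc1`, with dimethylamino in place of diethylamino on an aromatic carbon, gives > 100 ug/mL in this assay, also a limit. The step between them, a step that the two limits leave unreadable from compound 1 to compound 2, is therefore not readable. Compound 3 `O=C(Nc1cc2nc(C3CCCCC3)[nH]c2cc1N1CCCC1)c1ccccc1` gives > 100 ug/mL in this assay, a limit as well. All three values sit at the limit of > 100 ug/mL in this assay, at which 3 of the 3 values shown sit. Compound 4 `CCN(CC)c1cc2[nH]c(C3CCCCC3)nc2cc1NC(=O)c1ccc(Br)cc1` is not yet measured and differs from compound 1 in one place: bromo in place of difluoromethoxy on an aromatic carbon. For the measured compounds named here, no measured step bears on this change, and every value shown is a limit, so no size or direction can be read from them. Compound 4 is therefore expected to give 100 ug/mL in this assay, between 50 ug/mL and 200 ug/mL. This estimate means a step of a number no higher from compound 1 to compound 4 (the limit leaves the size open), expected to stay within the scatter.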

Compound 4, half-maximal inhibitory concentration: > 100 ug/mL
Compound 4: no number, only a limit; the forecaster's own chance of this, stated with the estimate: 85%; the middle value lies on the limit itself.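

No step from compound 1 to compound 4 can be read in this assay, since both values are limits of the assay rather than numbers: the limit of > 100 ug/mL in this assay, at which 4 of the 4 values shown sit.

The compounds shown leave open which structural change, if any, would give a number rather than a limit in this assay.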